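This account rests on a few compounds, and the source may have more. Where it says the series, first, only, none or still open, it means among the compounds named here.

Values in a functional assay on KBVIN cells (Homo sapiens) for antiproliferative activity, read by sulforhodamine B assay, with a stated time of 3 days (on this read-out lower numbers stand for an effect already at smaller amounts and higher numbers for an effect only at larger amounts of compound), for the three measured compounds:

Compound 1, `CCCc1ccc(-c2cc(=O)c3c(o2)C(CC)(CC)C(=O)C(CC)=C3O)cc1`, gives 12.2 uM.
Compound 2, `CCC1=C(O)c2c(oc(-c3ccc(C(C)C)cc3)cc2=O)C(CC)(CC)C1=O`, gives 1.08 uM.
Compound 3, `CCC1=C(O)c2c(oc(-c3ccc(OC)cc3)cc2=O)C(CC)(CC)C1=O`, gives 0.68 uM.

Compound 2 stands second highest of the three numbers. Its nearest neighbour is compound 3, reached by a step of a 1.6-fold lower number from compound 2 to compound 3 (0.20 log units; within the scatter), which is within the scatter; its furthest is compound 1, from which the step is an 11-fold lower number from compound 1 to compound 2 (1.05 log units; beyond the scatter), beyond the scatter.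

Compound 4, `CCC1=C(O)c2c(oc(-c3ccc(O)c(O)c3)cc2=O)C(CC)(CC)C1=O`, is not yet measured. Relative to compound 2 the change is 3,4-dihydroxyphenyl in place of 4-isopropylphenyl on an aromatic carbon.

The measured steps all concern the para substituent of the phenyl: an 11-fold lower number from compound 1 to compound 2 (1.05 log units; beyond the scatter) and an 18-fold lower number from compound 1 to compound 3 (1.25 log units; beyond the scatter) are large, whereas a 1.6-fold lower number from compound 2 to compound 3 (0.20 log units; within the scatter) is within the scatter. Going by the values given here, none of them introduces hydroxyl groups or a second substituent on the phenyl, so no measured step bears directly on this change; the only hint is that isopropyl and methoxy give numbers close to one another. For compound 4 a step of a 1.1-fold lower number from compound 2 to compound 4 (0.03 log units; within the scatter) is therefore expected, with no direction beyond the scatter supported. The estimate for compound 4 is 1 uM, in the range 0.3 uM to 4 uM.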

Compound 4, concentration for half-maximal effect: 5.41 uM
Beside the measured number, compound 4's estimate is 5.4-fold (0.73 log units) below it; the measured number lies above the stated range.
By their numbers in this assay, from the lowest: compounds 3 and 2 (each within the scatter of the next); then compound 4; then compound 1.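

In this assay the position does respond to a phenyl with two hydroxyls, which the earlier para-substituent steps could not show: the change gives a 5.0-fold higher number from compound 2 to compound 4 (0.70 log units; beyond the scatter) and also an 8.0-fold higher number from compound 3 to compound 4 (0.90 log units; beyond the scatter) against the two best-placed groups. It does not rank last, though, since the same change gives a 2.3-fold lower number from compound 1 to compound 4 (0.35 log units; beyond the scatter) against 4-propylphenyl, so compound 4 falls between the 4-propylphenyl compound and the other two, and the phenyl substituent sets the number over a wide span without a simple order. Nothing measured here accounts for these differences.

Going by these compounds, two hydroxyls enter together here, so the share of each remains open, and a phenyl carrying a single hydroxyl would separate them. On these data alone, how an amine or a carboxylic acid on the phenyl would compare also remains open.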